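Compound 4: replacing phenyl on the sulfur-bound chain

The source may hold more compounds than are shown below. What is called first, only, known or untested is meant among the compounds shown, and "the series" means these compounds.

In a functional assay on HepG2 cells (Homo sapiens) for inhibition, read by MTT assay, with a stated time of 48 h (a higher number here means a weaker inhibitor, a lower number a stronger inhibitor), compound 1 `COc1ccc(-n2c(SCc3ccccc3)nnc2-c2cc(OC)c(OC)c(OC)c2)cc1` gives > 60000 nM, which is a limit. Compound 2 `CCOC(=O)CSc1nnc(-c2cc(OC)c(OC)c(OC)c2)n1-c1ccc(OC)cc1` gives > 60000 nM, also a limit. Compound 3 `COc1cc(-c2nnc(SCc3ccccc3)n2-c2ccc(N(C)C)cc2)cc(OC)c1OC` gives > 60000 nM, again a limit, so it offers no number as a starting point. Among the compounds with values here, the series so far amounts to the limit of > 60000 nM in this assay, at which 3 of the 3 values shown sit.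

The measured changes are a step that the two limits leave unreadable from compound 1 to compound 2 and a step that the two limits leave unreadable from compound 1 to compound 3. Neither gives a size, so the expected direction, toward a stronger inhibitor, rests on the structural change alone.

Compound 4 `COc1ccc(C(=O)CSc2nnc(-c3cc(OC)c(OC)c(OC)c3)n2-c2ccc(N(C)C)cc2)cc1O` differs from compound 3 as follows: (3-hydroxy-4-methoxyphenyl)carbonyl in place of phenyl on a saturated chain carbon bound to a sulfur. Expected in this assay is an at least 4.0-fold lower number from compound 3 to compound 4 (0.60 log units; beyond the scatter), with a real chance of another limit. For compound 4 the estimate is 15000 nM, with an expected range of 1000 nM to 60000 nM.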

Compound 4, half-maximal inhibitory concentration: > 100000 nM
Compound 4: a limit, no number; the forecaster's own chance of this, stated with the estimate: 40%; middle value at least 6.6-fold (0.82 log units) from the limit.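

Within the data shown here, compound 4 gives > 100000 nM, a limit, and compound 3 is likewise only a limit, so no step from compound 3 to compound 4 can be read. The compounds shown leave open what substitution, if any, gives a measurable number in this assay.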